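The compounds below may be only part of what the source reports. "The series", "measured", "known", "first", "only" and "open" are said of these compounds alone.

Series notes. Compound 1 `C[C@@H](C(=O)N1CC2CC2C1)N1CCN(S(=O)(=O)c2ccc(C(C)(C)C)cc2)CC1`, compound 2 `C[C@@H](C(=O)N1CCC(F)(F)CC1)N1CCN(S(=O)(=O)c2ccc(C(C)(C)C)cc2)CC1` and compound 3 `CC(C(=O)N1CCC(C)(C)CC1)N1CCN(S(=O)(=O)c2ccc(C(C)(C)C)cc2)CC1` share one core and differ only in the amide group on the carbonyl carbon. In an ADME assay on HepG2 cells (Homo sapiens) for inhibition, with a stated time of 48 h (on this read-out lower numbers stand for an effect already at smaller amounts and higher numbers for an effect only at larger amounts of compound), compound 1 gives a limit of > 40000 nM. Compound 2 gives a limit of > 40000 nM in this assay. Compound 3 likewise gives a limit of > 40000 nM in this assay, so compound 3 stands with the other two at the limit of > 40000 nM in this assay, at which 3 of the 3 values shown sit. The step that the two limits leave unreadable from compound 1 to compound 2 is accordingly not readable. Compound 4 `CC(C(=O)N1CCc2ccccc2C1C)N1CCN(S(=O)(=O)c2ccc(C(C)(C)C)cc2)CC1` carries 1-methyl-1,2,3,4-tetrahydroisoquinolin-2-yl in place of 4,4-dimethylpiperidin-1-yl on a carbonyl carbon. For the measured compounds named here, no measured step with a readable size bears on this change, and no number gives a reference point. The expected step is therefore a number no higher from compound 3 to compound 4 (the limit leaves the size open), none beyond the scatter. For compound 4 the estimate in this assay is 40000 nM, ranging from 15000 nM to 100000 nM, most likely again reported only as a limit.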

Compound 4, half-maximal effective concentration: 28000 nM
Compound 4: middle estimate off by 1.4-fold (0.15 log units), on the high side; measured number inside the range.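

For the compounds shown here, compound 4 gives the first readable number at this position, so the amide group on the carbonyl carbon can bring the read-out inside the measurable range of this assay. On these data alone, the change gives an at least 1.4-fold lower number from compound 3 to compound 4 (0.15 log units; that floor lies within the scatter), and only this floor is known because compound 3 carries a limit, so the true size stays open. The other compounds give no number: the limit of > 40000 nM in this assay, at which 3 of the 4 values shown sit.

Open, as far as these compounds go, is whether the 1-methyl group or the aromatic ring of the entering group accounts for the number, which the plain 1,2,3,4-tetrahydroisoquinolin-2-yl group could separate. Also open, from the compounds shown here alone, is how an amine or a carboxylic acid in the amide group would read.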